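Lengthening the Side Chain of Compound 1

This account rests on a few compounds, and the source may have more. Where it says the series, first, only, none or still open, it means among the compounds named here.

Measured in a functional assay on HCT-116 cells (Homo sapiens) for antiproliferative activity, read by MTT assay, with a stated time of 48 h; on this read-out higher numbers stand for weaker inhibition and lower numbers for stronger inhibition:
compound 1 `CCCC(CCO)n1cnc2c(Cl)nc(F)nc21` gives 16500 nM
compound 2 `CCCC(CCO)n1cnc2c(Cl)ncnc21` gives > 50000 nM (a limit)
compound 3 `CCCCCC(CCO)n1cnc2c(N(C)C)ncnc21` gives > 50000 nM (a limit)

Going by the values given here, compound 1 is the only one with a true number. Compound 2 and compound 3 reach only (the limit of > 50000 nM in this assay, at which 2 of the 3 values shown sit).

Compound 4 `CCCCCCCC(CCO)n1cnc2c(Cl)nc(F)nc21` extends the chain of compound 1 from propyl to heptyl: butyl in place of hydrogen on a saturated chain carbon, four bonds along the chain from an aromatic nitrogen.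

Among the compounds with values here, the one measured step, an at least 3.0-fold higher number from compound 1 to compound 2 (0.48 log units; beyond the scatter), exchanges the fluoro for hydrogen. Compound 4 keeps that fluoro, so this step says nothing direct about the chain. Within the data shown here, no measured step touches the chain. Only a modest move toward stronger inhibition in this assay is therefore expected, tentatively: a 2.1-fold lower number from compound 1 to compound 4 (0.31 log units; beyond the scatter). Compound 4 is estimated at 8000 nM, with an expected range of 2000 nM to 32000 nM.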

Compound 4, half-maximal inhibitory concentration: 17600 nM
Compound 4: the middle estimate sits 2.2-fold (0.34 log units) below what was measured; low and high end bracket the measured number.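

In this assay, butyl in place of hydrogen at this position gives a 1.1-fold higher number from compound 1 to compound 4 (0.03 log units; within the scatter), so going from propyl to heptyl brings no real difference in the read-out. Going by these compounds alone, this is the first comparison that touches the chain, and it shows that, with the fluoro kept, the added length neither helps nor harms here. Nothing shown explains why the number stays flat.

Still open, from the compounds shown here alone, is whether a chain longer than heptyl would also read the same. Also open, going by these compounds, is whether an amine or a carboxylic acid in place of the butyl would change the number.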